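Cyanomethyl in Place of Hydrogen, Made a Second Time

The source may hold more compounds than are shown below. What is called first, only, known or untested is meant among the compounds shown, and "the series" means these compounds.

Compound 3 `COC1(c2csc(Sc3ccc4c(c3)CC/C4=N\O)c2)CCOCC1` and compound 1 `COC1(c2csc(Sc3ccc4c(c3)CC/C4=N\OCC#N)c2)CCOCC1` share one core and differ only by cyanomethyl in place of hydrogen on an oxygen. In a functional assay (blood) for inhibition, with Homo sapiens as the target (on this read-out higher numbers stand for weaker inhibition and lower numbers for stronger inhibition), compound 3 gives 130 nM, while compound 1 gives 40 nM; that change made a 3.3-fold lower number from compound 3 to compound 1 (0.51 log units; beyond the scatter). Compound 2 `CO[C@]1(c2cc(F)cc(Sc3ccc(/C(C)=N/O)cc3)c2)CCO[C@@H](C)C1` sits on another core, and how that core differs from the core of compound 3 is not broken down here. In this assay compound 2 gives 40 nM, level with compound 1 at the digits given. Compound 4 `CO[C@]1(c2cc(F)cc(Sc3ccc(/C(C)=N/OCC#N)cc3)c2)CCO[C@@H](C)C1` is not yet measured; it differs from compound 2 by cyanomethyl in place of hydrogen on an oxygen, the same change at the same place. Because the earlier step gave a 3.3-fold lower number from compound 3 to compound 1 (0.51 log units; beyond the scatter), compound 4 is expected to reach about 15 nM, between 6 nM and 40 nM. For compound 4 the expected step is a 2.7-fold lower number from compound 2 to compound 4 (0.43 log units; beyond the scatter), resting on a single precedent on a different core.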

Compound 4, half-maximal inhibitory concentration: 40 nM
Compound 4: the middle estimate sits 2.7-fold (0.43 log units) below what was measured; the range from low to high includes it.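

On the second core, cyanomethyl in place of hydrogen on an oxygen gave no change at the digits printed from compound 2 to compound 4 (within the scatter) in this assay. The change did not carry over from one core to the other at the same size: the same change on two cores in this assay, a 3.3-fold lower number (0.51 log units; beyond the scatter) from compound 3 to compound 1 and no change at the digits printed (within the scatter) from compound 2 to compound 4, 3.3-fold (0.51 log units) apart, beyond the scatter of two such steps

This shows that the size of the step depended on the core in these two pairs, but it does not show which feature of the cores is responsible, and two pairs set no rule for the whole series. The compounds shown leave open whether a different group on the same oxygen, such as methyl or a longer chain ending in a carboxylic acid, would also depend on the core. They also leave open how cyanomethyl would behave on a third core.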